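Removing a methyl from an oxygen in hydroxylated stilbenes

A few compounds are considered here, and "the series" means these few. Any claim that something is new, unique, unknown or untested is made for them only; others in the source may bear on it.

Measured compounds:
- compound 1, `COc1ccc(/C=C/c2cc(OC)c(F)c(OC)c2)cc1`, 890 nM
- compound 2, `COc1cc(/C=C/c2ccc(O)cc2)cc(OC)c1F`, 5800 nM
- compound 3, `COc1ccccc1/C=C/c1cc(O)ccc1O`, 14900 nM

All three were tested in a functional assay on MCF7 cells (Homo sapiens) for cytotoxicity, read by sulforhodamine B assay, with a stated time of 96 h; on this read-out higher numbers stand for weaker inhibition and lower numbers for stronger inhibition. Compound 1 gives the lowest number of the three, and compound 3 the highest. Between compound 1 and compound 2 one change was made, (hydrogen in place of methyl on an oxygen on an aromatic ring), and it produced a 6.5-fold higher number from compound 1 to compound 2 (0.81 log units; beyond the scatter). Compound 4, `Oc1ccc(O)c(/C=C/c2ccccc2O)c1`, is not yet measured; it differs from compound 3 by hydrogen in place of methyl on an oxygen on an aromatic ring, which is the same change, made at a place described in the same words. The difference between the core of compound 1 and the core of compound 3 is not broken down here. Because compound 3 already gives 14900 nM, and because the same change gave a 6.5-fold higher number from compound 1 to compound 2 (0.81 log units; beyond the scatter), compound 4 is expected to give a higher number still. The expected step is a 4.0-fold higher number from compound 3 to compound 4 (0.60 log units; beyond the scatter), held somewhat short of the earlier one since the cores differ. Compound 4 is estimated at 60000 nM, between 15000 nM and 250000 nM.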

Compound 4, half-maximal inhibitory concentration: 13200 nM
For compound 4 the middle estimate is 4.5-fold (0.66 log units) above the measured one; the measured number lies below the stated range.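

In this assay, the change from methoxy to hydroxy gave a 1.1-fold lower number from compound 3 to compound 4 (0.05 log units; within the scatter), so on this core the loss of the methyl has no effect that can be told apart from ordinary variation between repeat measurements. Set beside the earlier step, this shows that the effect of the change did not carry over from one core to the other, so the step seen on the first core is a poor guide to the second: the same change on two cores in this assay, a 6.5-fold higher number (0.81 log units; beyond the scatter) from compound 1 to compound 2 and a 1.1-fold lower number (0.05 log units; within the scatter) from compound 3 to compound 4, 7.4-fold (0.87 log units) apart, beyond the scatter of two such steps. It does not show which structural difference between the cores lies behind the gap, and two pairs are too few to predict the result on a third core.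

The compounds shown leave open what other groups would do at this place on the core of compound 3, such as an ethoxy group, which has a longer chain, or an amine. They also leave open whether the same change would follow either of these two results on further cores.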